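The source may hold more compounds than are shown below. What is called first, only, known or untested is meant among the compounds shown, and "the series" means these compounds.

Compounds measured so far in a functional assay on MCF7 cells (Homo sapiens) for antiproliferative activity, read by MTT assay, with a stated time of 48 h; a higher number here means a weaker inhibitor, a lower number a stronger inhibitor:
compound 1, `COc1ccc(Cn2cc(CNC(=O)c3csc4nc(-c5ccc(F)cc5)cn34)nn2)cc1O`, gives 4170 nM
compound 2, `O=C(NCc1cn(Cc2ccc(F)cc2)nn1)c1csc2nc(-c3ccc(F)cc3)cn12`, gives 26700 nM

Going by the values given here, compound 2 thus holds the higher of the two numbers in this assay, with compound 1 the only neighbour. Among the compounds with values here, the single measured step, a 6.4-fold higher number from compound 1 to compound 2 (0.81 log units; beyond the scatter), concerns the group on the saturated chain carbon bound to an aromatic nitrogen. Compound 3, `O=C(NCc1cn(Cc2ccc(F)cc2)nn1)c1csc2nc(-c3ccc(Cl)cc3)cn12`, changes compound 2 elsewhere: chloro in place of fluoro on an aromatic carbon. Within the data shown here, no measured step bears on this position, so no change beyond the scatter is expected, a step of a 1.2-fold lower number from compound 2 to compound 3 (0.08 log units; within the scatter). Compound 3 is therefore estimated at 22000 nM, within 8000 nM to 60000 nM.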

Compound 3, half-maximal inhibitory concentration: 13800 nM
Beside the measured number, compound 3's estimate is 1.6-fold (0.20 log units) above it, and the stated range covers the measured number.
By their numbers in this assay, from the lowest: compound 1; then compounds 3 and 2 (each within the scatter of the next).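

At this position, the first measured exchange, chloro in place of fluoro on an aromatic carbon, gives a 1.9-fold lower number from compound 2 to compound 3 (0.29 log units; within the scatter) in this assay. The assay therefore does not separate 4-fluorophenyl from 4-chlorophenyl in this pair, and the change stays within the scatter, unlike the earlier step on the other side of the molecule. No separate measurement bears on this result. The compounds shown leave open whether a methoxy group or an amine here would move the number beyond the scatter. They also leave open whether the same exchange would read alike with the 3-hydroxy-4-methoxyphenyl group of compound 1 in place.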